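The source may hold more compounds than are shown below. What is called first, only, known or untested is meant among the compounds shown, and "the series" means these compounds.

Compound 1 `CCCOC(=O)C1=C(C)NC(C)=C(C(=O)OC)C1c1[nH]c(CC)nc1Cl` is the reference point here; in an assay on ileum for inhibition of Voltage-dependent L-type calcium channel subunit alpha-1C (Cavia porcellus) (a lower number here means a stronger inhibitor, a higher number a weaker inhibitor), compound 1 gives 0.146 nM. Among the three measured numbers this is the second highest. Compound 2 `CCCOC(=O)C1=C(C)NC(C)=C(C(=O)OCCC)C1c1[nH]c(CC)nc1Cl` gives 0.13 nM, a value within the scatter of compound 1, whereas compound 3 `CCc1nc(Cl)c(C2C(C(=O)OC(C)C)=C(C)NC(C)=C2C(=O)OC(C)C)[nH]1` gives 0.748 nM, a number beyond the scatter and higher than that of compound 1. The change to compound 4 `CCc1nc(Cl)c(C2C(C(=O)OC)=C(C)NC(C)=C2C(=O)OC(C)(C)C)[nH]1` is tert-butyl in place of propyl on an oxygen next to a carbonyl group. Within the data shown here, only one measured step touches the same place: a 1.1-fold lower number from compound 1 to compound 2 (0.05 log units; within the scatter), which leaves this assay unmoved. Among the measured compounds shown here, no measured step adds a tert-butyl or any other branched group, and for the pair compound 1 and compound 3 no single-change step exists; their two values show only that the compound with two isopropyl esters sits at a clearly higher number than the one with methyl plus propyl. For the measured compounds named here, with that as the sole guide, a rise in the number is expected for compound 4, smaller than the whole gap to compound 3 since only one ester changes, but with wide uncertainty. Compound 4 is therefore estimated at 0.5 nM, with a range of 0.12 nM to 2.5 nM, meaning an expected step of a 3.4-fold higher number from compound 1 to compound 4 (0.53 log units; beyond the scatter).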

Compound 4, half-maximal inhibitory concentration: 50.8 nM
Estimate against measurement, compound 4: 100-fold (2.01 log units) below; the whole stated range lies below it.
By their numbers in this assay, from the lowest: compounds 2 and 1 (each within the scatter of the next); then compound 3; then compound 4.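

In this assay, among these compounds, tert-butyl in place of propyl on an oxygen next to a carbonyl group gives a 350-fold higher number from compound 1 to compound 4 (2.54 log units; beyond the scatter), the only large step so far. The earlier step, a 1.1-fold lower number from compound 1 to compound 2 (0.05 log units; within the scatter), had shown an ester chain growing with no readable change, whereas here the count moves only from 3 heavy atoms to 4 and the number rises steeply, so the identity of the group on this oxygen matters far more than its carbon count suggests. Nothing shown gives a measured reason for this jump.

The compounds shown leave open whether the rise follows gradually from the degree of branching or appears only with tert-butyl, a question that isopropyl, sec-butyl or neopentyl on this same oxygen, with the methyl ester and the rest of compound 1 kept, would help settle. Also open, as far as these compounds go, is how this place responds to a longer straight chain such as pentyl, or to a ring such as cyclohexyl, and whether tert-butyl has the same effect when the other ester is propyl rather than methyl.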